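This account rests on a few compounds, and the source may have more. Where it says the series, first, only, none or still open, it means among the compounds named here.

Working notes on the series, all read in a functional assay on PC-3 cells (Homo sapiens) for inhibition, read by MTT assay, with a stated time of 48 h; a lower number here means a stronger inhibitor, a higher number a weaker inhibitor. Compound 1 (`COc1ccc(-n2c(SCc3ccc(C)cc3)nnc2-c2cc(OC)c(OC)c(OC)c2)cc1`) gives 56500 nM, and compound 2 (`COc1ccc(CSc2nnc(-c3cc(OC)c(OC)c(OC)c3)n2-c2ccc(OC)cc2)cc1`) gives 40300 nM. Compound 3 (`COc1ccc(-n2c(SCC(=O)c3ccccc3)nnc2-c2cc(OC)c(OC)c(OC)c2)cc1`) gives > 60000 nM, which is a limit of the assay and not a number. Its standing is thus (the limit of > 60000 nM in this assay, at which 1 of the 3 values shown sits).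

Compound 4 (`COc1ccc(-n2c(SCC(=O)c3ccc(F)cc3)nnc2-c2cc(OC)c(OC)c(OC)c2)cc1`) is compound 3 with fluoro in place of hydrogen on an aromatic carbon, para to a large group: fluoro in place of hydrogen on an aromatic carbon. The benzoyl becomes (4-fluorophenyl)carbonyl.

For the measured compounds named here, no measured step makes this exact change. The nearest is a swap of methoxy in place of methyl on an aromatic carbon, a 1.4-fold lower number from compound 1 to compound 2 (0.15 log units; within the scatter). The two steps that introduce benzoyl, an at least 1.0-fold higher number from compound 1 to compound 3 (0.02 log units; that floor lies within the scatter) and an at least 1.4-fold higher number from compound 2 to compound 3 (0.17 log units; that floor lies within the scatter), give only floors, and both floors lie within the scatter. With so little movement in this assay, and with the starting point only a limit, no shift beyond the scatter is expected, in either direction. The estimated step is a number no higher from compound 3 to compound 4 (the limit leaves the size open). A second limit reading would not be surprising. For compound 4 the estimated value is 60000 nM, with an expected range of 30000 nM to 110000 nM.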

Compound 4, half-maximal inhibitory concentration: 58300 nM
Compound 4: middle estimate off by 1.0-fold (0.01 log units), on the high side; measured number inside the range.
By their numbers in this assay, from the lowest: compounds 2, 1 and 4 (each within the scatter of the next). At a limit, above all of these: compound 3.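

Compound 3 stands at a limit of the assay and not at a number, and the change to (4-fluorophenyl)carbonyl can be read from it only as a floor: the limit of > 60000 nM in this assay, at which 1 of the 4 values shown sits.
Fluoro in place of hydrogen gives an at least 1.0-fold lower number from compound 3 to compound 4 (0.01 log units; that floor lies within the scatter) and, with compound 4, provides a number in this assay for a chain carrying a carbonyl on the carbon bound to the sulfur. That number allows direct comparison with the two arylmethyl compounds, and neither step leaves the scatter (a 1.4-fold higher number from compound 2 to compound 4 (0.16 log units; within the scatter); a 1.0-fold higher number from compound 1 to compound 4 (0.01 log units; within the scatter)), so (4-fluorophenyl)carbonyl cannot be told apart from 4-methoxyphenyl or 4-methylphenyl at this position.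

Still open, on these data alone, is whether any change at this position can move the number beyond the scatter, for example an amine or a carboxylic acid in place of fluoro at the same place on the ring, or a longer chain between the sulfur and the ring. As far as these compounds go, the effect of changes to the shared core also remains open, as all four compounds carry it unaltered.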